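Swapping a benzyl ester for a methyl thioether

This account rests on a few compounds, and the source may have more. Where it says the series, first, only, none or still open, it means among the compounds named here.

Compound 2 `O=C(CN(c1nc(Cl)nc2[nH]cnc12)C1CC1)N[C@@H](CCC(=O)OCc1ccccc1)C(=O)OCc1ccccc1` was tested in a functional assay on the whole organism (Tail, strain ICR) with Mus musculus as the target, in the tail flick test, with a stated time of 120 min, at a dose of 25 umol/kg by the oral route (on this read-out lower numbers stand for a weaker effect and higher numbers for a stronger effect at the one dose given), and gives 45.9%. Compound 1 `C[C@H](NC(=O)CN(c1nc(Cl)nc2[nH]cnc12)C1CC1)C(=O)OCc1ccccc1` gives 36.1% in the same assay. Among the compounds with values here, of the two numbers measured, that of compound 2 is the higher, but the only step of a number 9.8 percentage points higher from compound 1 to compound 2 (within the scatter) lies within the scatter, so the two compounds cannot be told apart on this read-out. Compound 3 `CSCC[C@H](NC(=O)CN(c1nc(Cl)nc2[nH]cnc12)C1CC1)C(=O)OCc1ccccc1` has not yet been measured. It differs from compound 2 by methylsulfanyl in place of benzyloxycarbonyl on a saturated chain carbon, three bonds along the chain from an amide-type nitrogen and a carbonyl carbon. Within the data shown here, the one measured step, a number 9.8 percentage points higher from compound 1 to compound 2 (within the scatter), changed a group in the same side-chain region and was within the scatter, so a change of similar or smaller size is expected here, with no clear direction. Compound 3 is therefore estimated to give 40%, within a range of 25% to 56%, a step from compound 2 of a number 5.9 percentage points lower from compound 2 to compound 3 (within the scatter) that is expected to stay within the scatter.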

Compound 3, a percentage reported as activity, at one dose (the size of the read-out at that dose, not a potency): 31.6%
Beside the measured number, compound 3's estimate is 8.4 percentage points above it; the measured number falls inside the stated range.
By their numbers in this assay, from the lowest: compounds 3, 1 and 2 (each within the scatter of the next, the first and the last beyond it).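

In this assay, this side chain now shows a change that can be told from the scatter: benzyloxycarbonyl, with its aromatic ring and 10 heavy atoms, gives way to methylsulfanyl, with 2 heavy atoms, and the result is a number 14.3 percentage points lower from compound 2 to compound 3 (beyond the scatter) on the same chain carbon. The chain is not simply free to change, yet the smaller replacement does not separate itself from the simplest compound, as (methylsulfanyl)methyl in place of hydrogen gives a number 4.5 percentage points lower from compound 1 to compound 3 (within the scatter) and so cannot be told from no change on this read-out. No measurement shown here explains the difference between these groups.

As far as these compounds go, it remains open whether the aromatic ring or the ester of benzyloxycarbonyl matters for the difference between compound 2 and compound 3. From the compounds shown here alone, how a carboxylic acid, an amine or a longer chain would read at this place also remains open.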